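The compounds below may be only part of what the source reports. "The series", "measured", "known", "first", "only" and "open" are said of these compounds alone.

Compound 1, `CN(C)CC(=O)N1CCC(NS(=O)(=O)c2cc(S(=O)(=O)c3ccccc3)ccc2C(F)(F)F)CC1`: 100000 nM
Compound 2, `O=C(CN1CCNCC1)N1CCC(NS(=O)(=O)c2cc(S(=O)(=O)c3ccccc3)ccc2C(F)(F)F)CC1`: 50000 nM
Compound 3, `CC(=O)N1CCC[C@H]1C(=O)N1CCC(NS(=O)(=O)c2cc(S(=O)(=O)c3ccccc3)ccc2C(F)(F)F)CC1`: 12500 nM

In a physicochemical assay for solubility (a higher number here means a more soluble compound, a lower number a less soluble compound), compound 3 gives 12500 nM, the lowest of the three numbers. Its distance from the others is real: an 8.0-fold lower number from compound 1 to compound 3 (0.90 log units; beyond the scatter), and a 4.0-fold lower number from compound 2 to compound 3 (0.60 log units; beyond the scatter). Between the two higher compounds the gap is small: a 2.0-fold lower number from compound 1 to compound 2 (0.30 log units; within the scatter).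

Compound 4, `CN(C)C(=O)N1CCC[C@H]1C(=O)N1CCC(NS(=O)(=O)c2cc(S(=O)(=O)c3ccccc3)ccc2C(F)(F)F)CC1`, is the next step from compound 3. The change is dimethylamino in place of methyl on a carbonyl carbon, on a carbonyl carbon whose other neighbour is an amide-type nitrogen in a ring; cut one bond further out it reads acetyl to dimethylcarbamoyl. For the measured compounds named here, no measured step alters this part of the molecule. The two steps that reach compound 3 each swap the entire group on the other carbonyl carbon, and they moved this assay by a modest amount; the present exchange is smaller in scope. Compound 4 is therefore expected to stay close to compound 3, with no change at the digits printed from compound 3 to compound 4 (within the scatter) not beyond the scatter. The estimate for compound 4 is 12500 nM, expected to lie between 5000 nM and 30000 nM.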

Compound 4, solubility: 100000 nM
Compound 4: the middle estimate sits 8.0-fold (0.90 log units) below what was measured; the measured number lies above the stated range.
By their numbers in this assay, from the lowest: compound 3; then compounds 2, 1 and 4 (each within the scatter of the next).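

In this assay, for the compounds shown here, the earlier steps all swapped the entire group on the other carbonyl carbon, whereas dimethylamino in place of methyl on the carbonyl carbon of the acetyl group gives an 8.0-fold higher number from compound 3 to compound 4 (0.90 log units; beyond the scatter), showing that this position responds to a change of only a few heavy atoms. The other two steps, a 2.0-fold higher number from compound 2 to compound 4 (0.30 log units; within the scatter) and no change at the digits printed from compound 1 to compound 4 (within the scatter), lie within the scatter, so among these compounds the low number of compound 3 goes with its 1-acetylpyrrolidin-2-yl group and does not extend to the 1-(dimethylcarbamoyl)pyrrolidin-2-yl group. Nothing shown here gives a measured reason for this step.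

As far as these compounds go, it remains open whether a methoxy group, an ethyl chain or a primary amine on this carbonyl carbon would give a number near that of compound 3 or that of compound 4. From the compounds shown here alone, whether the step from methyl to dimethylamino would be similar on a core without the pyrrolidin-2-yl unit also remains open.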